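The compounds below may be only part of what the source reports. "The series", "measured", "known", "first", "only" and "open" are said of these compounds alone.

In a functional assay on BMMC cells (Mus musculus, strain C57BL/6) for inhibition, with stated times of 5 days and 48 h (a lower number here means a stronger inhibitor, a higher number a weaker inhibitor), compound 1 `C=C1CC[C@@H]2[C@](C)(CNCc3ccccc3)[C@H](O)CC[C@@]2(C)[C@@H]1/C=C/C1=CCOC1=O` gives 960 nM, and compound 2 `C=C1CC[C@@H]2[C@](C)(CNCc3cccc(OC)c3)[C@H](O)CC[C@@]2(C)[C@@H]1/C=C/C1=CCOC1=O` gives 780 nM; the step of a 1.2-fold lower number from compound 1 to compound 2 (0.09 log units; within the scatter) is unremarkable. Compound 3 `C=C1CC[C@@H]2[C@](C)(CNCc3ccc(O)c(O)c3)[C@H](O)CC[C@@]2(C)[C@@H]1/C=C/C1=CCOC1=O` gives 9440 nM in this assay, the highest of the three numbers: its nearest neighbour is compound 1 and its furthest is compound 2, and both gaps lie beyond the scatter. The two measured steps that lead to compound 3, a 9.8-fold higher number from compound 1 to compound 3 (0.99 log units; beyond the scatter) and a 12-fold higher number from compound 2 to compound 3 (1.08 log units; beyond the scatter), are the ones that bear on the next compound.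

Compound 4 `C=C1CC[C@@H]2[C@](C)(CNCc3ccc(Cl)cc3)[C@H](O)CC[C@@]2(C)[C@@H]1/C=C/C1=CCOC1=O` has not yet been measured. Against compound 3 the difference is 4-chlorophenyl in place of 3,4-dihydroxyphenyl on a saturated chain carbon bound to an amine nitrogen. Going by the values given here, the 3,4-dihydroxyphenyl that leaves is the very group whose entry raised the number in both measured steps; the 4-chlorophenyl that enters has no measured counterpart, so the phenyl and 3-methoxyphenyl compounds are the only guide, and a chloro substituent remains an untested variable. A return toward the values of compound 1 and compound 2 is therefore expected in this assay, with a step down beyond the scatter rather than none. The expected step is a 10-fold lower number from compound 3 to compound 4 (1.02 log units; beyond the scatter). Compound 4 is estimated at 900 nM in this assay, within a range from 350 nM to 2500 nM.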

Compound 4, half-maximal inhibitory concentration: 420 nM
Compound 4: the middle estimate sits 2.1-fold (0.33 log units) above what was measured; low and high end bracket the measured number.
By their numbers in this assay, from the lowest: compounds 4, 2 and 1 (each within the scatter of the next, the first and the last beyond it); then compound 3.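

In this assay, the 3,4-dihydroxyphenyl group on the saturated chain carbon bound to an amine nitrogen now stands apart from three other aryl groups, as its replacement by 4-chlorophenyl gives the large step (a 22-fold lower number from compound 3 to compound 4 (1.35 log units; beyond the scatter)), so the high number of compound 3 is not shared by every substituted aromatic member. Chloro in place of hydrogen on an aromatic carbon is also the first substituent here to give a step beyond the scatter from the unsubstituted phenyl compound (a 2.3-fold lower number from compound 1 to compound 4 (0.36 log units; beyond the scatter)), although the step is modest, and 4-chlorophenyl is not separated from 3-methoxyphenyl (a 1.9-fold lower number from compound 2 to compound 4 (0.27 log units; within the scatter)). No measurement shown here explains these differences in the number.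

The compounds shown do not separate the contribution of each hydroxyl, so 3-hydroxyphenyl, 4-hydroxyphenyl and 3,4-dimethoxyphenyl would show whether one hydroxyl or the pair goes with the higher number. They also leave open whether the step from hydrogen to chloro depends on the halogen or its location, which 4-fluorophenyl, 4-bromophenyl and 3-chlorophenyl would test.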